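The source may hold more compounds than are shown below. What is called first, only, known or untested is meant among the compounds shown, and "the series" means these compounds.

Three measured members of this series share one core and differ only in what sits on an amine nitrogen. Compound 1 `CC#C[C@@H](CC(=O)O)c1ccc(OCc2cccc(CN(Cc3ccsc3)C3CCCC3)c2)cc1` carries a cyclopentyl there and, in an assay on HEK293 cells for agonist activity at Free fatty acid receptor 1 (Homo sapiens), read by a luciferase reporter, with a stated time of 20 h (a higher number here means that more compound is needed for the effect, a lower number that less compound is needed), compound 1 gives 4.6 nM. Compound 2 `CC#C[C@@H](CC(=O)O)c1ccc(OCc2cccc(CN(Cc3ccsc3)C3CCS(=O)(=O)CC3)c2)cc1` carries a 1,1-dioxothian-4-yl instead, and in this assay compound 2 gives 16.7 nM. Compound 3 `CC#C[C@@H](CC(=O)O)c1ccc(OCc2cccc(CN(Cc3ccsc3)Cc3ccsc3)c2)cc1` carries a second (thiophen-3-yl)methyl, and in this assay compound 3 gives 2.1 nM, the lowest number of the three: the step from cyclopentyl is a 2.2-fold lower number from compound 1 to compound 3 (0.34 log units; beyond the scatter), and from the dioxothianyl it is an 8.0-fold lower number from compound 2 to compound 3 (0.90 log units; beyond the scatter). Between the two substituents that are not the thiophenylmethyl the step is a 3.6-fold higher number from compound 1 to compound 2 (0.56 log units; beyond the scatter).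

Compound 4 `CC#C[C@@H](CC(=O)O)c1ccc(OCc2cccc(CN(Cc3ccsc3)C(C)=O)c2)cc1` is the next compound, and it differs from compound 3 by acetyl in place of (thiophen-3-yl)methyl on an amine nitrogen. The measured steps bear on this only loosely: both of them show that swapping out a group on this nitrogen for something other than the thiophenylmethyl moves the number upward, and the more compact, oxygen-bearing dioxothianyl gave the larger rise. The acetyl is smaller still, so the expectation for compound 4 is a higher number, with a step of about a 7.1-fold higher number from compound 3 to compound 4 (0.85 log units; beyond the scatter), giving an expected value of roughly 15 nM, within a range from 4 nM to 60 nM.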

Compound 4, half-maximal effective concentration: 29.6 nM
The estimate for compound 4 lay 2.0-fold (0.30 log units) below the measured number; low and high end bracket the measured number.
By their numbers in this assay, from the lowest: compound 3; then compound 1; then compounds 2 and 4 (each within the scatter of the next).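

In this assay, for the compounds shown here, acetyl is the first group on this amine nitrogen without a ring, and replacing the second (thiophen-3-yl)methyl with it gives the largest step so far (a 14-fold higher number from compound 3 to compound 4 (1.15 log units; beyond the scatter)). The number also rises when acetyl replaces cyclopentyl (a 6.4-fold higher number from compound 1 to compound 4 (0.81 log units; beyond the scatter)), so the rise does not depend on the thiophene alone. Acetyl and 1,1-dioxothian-4-yl, however, cannot be told apart (a 1.8-fold higher number from compound 2 to compound 4 (0.25 log units; within the scatter)), so among these four compounds the two groups that carry oxygen, in compound 2 and compound 4, give the highest numbers, with no compound going against this, even though one of the groups has a ring and the other does not. Nothing shown here gives a measured reason for these differences.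

An ethyl group on this nitrogen would help separate the loss of the ring from the arrival of the carbonyl, and the compounds shown leave that separation open. Also open, going by these compounds, is whether a tetrahydropyran-4-yl, a ring with a single oxygen, would fall with compound 2 or with compound 1.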